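Substituent on the ring nitrogen and MCF7 inhibition

The source may report more compounds than this note shows. Statements on the series, on what has been measured and on what is new or still open speak of the compounds shown alone.

Compound 1 `CCOC(=O)C1=Cc2ccccc2OC1(OCc1cn(-c2ccc(C)cc2)nn1)C(F)(F)F` carries 4-methylphenyl on the aromatic nitrogen; in a functional assay on MCF7 cells (Homo sapiens) for inhibition, read by MTT assay, with a stated time of 24 h (a lower number here means a stronger inhibitor, a higher number a weaker inhibitor), compound 1 gives 26700 nM. Compound 2 `CCOC(=O)C1=Cc2ccccc2OC1(OCc1cn(CC(=O)Nc2ccccc2F)nn1)C(F)(F)F` carries ((2-fluorophenyl)carbamoyl)methyl on that nitrogen, and in this assay compound 2 gives 42100 nM; the step between them is a 1.6-fold higher number from compound 1 to compound 2 (0.20 log units; within the scatter). Compound 3 `CCOC(=O)C1=Cc2ccccc2OC1(OCc1cn(-c2cccc(C(F)(F)F)c2)nn1)C(F)(F)F` carries 3-(trifluoromethyl)phenyl. In this assay compound 3 reaches only a limit, > 150000 nM, so no number is known for it. Against the two numbered compounds the steps are an at least 5.6-fold higher number from compound 1 to compound 3 (0.74 log units; beyond the scatter) and an at least 3.5-fold higher number from compound 2 to compound 3 (0.55 log units; beyond the scatter), so compound 3 sits at the weak end of what has been measured, on (the limit of > 150000 nM in this assay, at which 1 of the 3 values shown sits).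

Compound 4 `CCOC(=O)C1=Cc2ccccc2OC1(OCc1cn(CC(=O)Nc2cccc(Cl)c2)nn1)C(F)(F)F` differs from compound 3 by ((3-chlorophenyl)carbamoyl)methyl in place of 3-(trifluoromethyl)phenyl on an aromatic nitrogen. The measured step that bears on this is an at least 3.5-fold higher number from compound 2 to compound 3 (0.55 log units; beyond the scatter), read in reverse: going from an aryl group back to a carbamoylmethyl group on the aromatic nitrogen. Among the measured compounds shown here, the aryl part of the amide in compound 4 is 3-chlorophenyl rather than 2-fluorophenyl, and no measured pair tests that difference. The expectation is therefore a lower number, estimated as an at least 3.3-fold lower number from compound 3 to compound 4 (0.52 log units; beyond the scatter). Compound 4 is expected to give about 45000 nM, within 18000 nM to 130000 nM.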

Compound 4, half-maximal inhibitory concentration: 11600 nM
Compound 4: middle estimate off by 3.9-fold (0.59 log units), on the high side; measured number below the stated range.
By their numbers in this assay, from the lowest: compound 4; then compounds 1 and 2 (each within the scatter of the next). At a limit, above all of these: compound 3.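

The first sentence's comparison is new: with the carbamoylmethyl chain kept, 3-chlorophenyl in place of 2-fluorophenyl gives a 3.6-fold lower number from compound 2 to compound 4 (0.56 log units; beyond the scatter) in this assay, so the aryl group of the amide changes the reading at this position. The earlier carbamoylmethyl example did not separate from the 4-methylphenyl example, whereas ((3-chlorophenyl)carbamoyl)methyl in place of 4-methylphenyl gives a 2.3-fold lower number from compound 1 to compound 4 (0.36 log units; beyond the scatter), so this result holds for the 3-chlorophenyl amide and not for the 2-fluorophenyl amide. Replacing 3-(trifluoromethyl)phenyl with the same group gives an at least 12-fold lower number from compound 3 to compound 4 (1.11 log units; beyond the scatter), and that figure is a bound, one end of it being a limit of the assay: the limit of > 150000 nM in this assay, at which 1 of the 4 values shown sits.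

As far as these compounds go, the 2-fluorophenyl and 3-chlorophenyl amides differ in both the halogen and its place on the ring, so it remains open which of the two carries the step; a chlorophenyl and a fluorophenyl amide with the halogen placed alike would separate them. Also open, from the compounds shown here alone, is how a methylated amide nitrogen, a carboxylic acid or a longer chain in place of the carbamoylmethyl group would read in this assay.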